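Ring-nitrogen substituents in the carbamate series: compound 4

The source may report more compounds than this note shows. Statements on the series, on what has been measured and on what is new or still open speak of the compounds shown alone.

compound 1 `O=C1COCC(NC(=O)OCc2ccccc2)C(=O)N1`: 81.3 mg/kg
compound 2 `C=CCN1C(=O)COCC(NC(=O)OCc2ccccc2)C1=O`: 70.3 mg/kg
compound 3 `O=C(NC1COCC(=O)N(Cc2ccccc2)C1=O)OCc1ccccc1`: only a limit, > 100 mg/kg

In a functional assay on the whole organism (strain ICR) with Mus musculus as the target, in the maximal electroshock model, with a stated time of 30 min (a higher number here means that more compound is needed for the effect, a lower number that less compound is needed), compound 1 gives 81.3 mg/kg. Compound 2 gives 70.3 mg/kg. Among the compounds with values here, for compound 3 the assay reports only a limit, > 100 mg/kg, so compound 3 is the one value sitting at the limit of > 100 mg/kg in this assay, at which 1 of the 3 values shown sits. On the numbers shown compound 3 thus stands at the upper edge of the series, but only as a limit. The three measured steps are all small: a 1.2-fold lower number from compound 1 to compound 2 (0.06 log units; within the scatter), an at least 1.2-fold higher number from compound 1 to compound 3 (0.08 log units; that floor lies within the scatter) and an at least 1.4-fold higher number from compound 2 to compound 3 (0.15 log units; that floor lies within the scatter); none reaches beyond the scatter.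

The step under consideration leads to compound 4 `O=C(NC1COCC(=O)N(Cc2ccco2)C1=O)OCc1ccccc1`. The change is furan-2-yl in place of phenyl on a saturated chain carbon bound to an amide-type nitrogen in a ring. Within the data shown here, no measured step swaps one aromatic ring for another; the nearest is the one that places a phenyl where a vinyl stood, an at least 1.4-fold higher number from compound 2 to compound 3 (0.15 log units; that floor lies within the scatter), and its floor lies within the scatter. The change from compound 3 to compound 4 is therefore expected to give no step beyond the scatter in this assay, with a fair chance that compound 4 again returns only a limit. Compound 4 is estimated at 110 mg/kg. The range for compound 4 is estimated from 40 mg/kg to 300 mg/kg. This estimate corresponds to an expected step that the limit leaves unreadable from compound 3 to compound 4.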

Compound 4, dose for half-maximal effect: > 100 mg/kg
Compound 4 ended at the assay's limit (the forecaster's own chance of this, stated with the estimate: 60%); the middle value lies beyond the limit too.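

In this assay compound 4 gives only a limit, > 100 mg/kg, so a second aromatic group on the saturated chain carbon bound to the amide-type nitrogen in the ring ends at the same limit as the benzyl group of compound 3: the limit of > 100 mg/kg in this assay, at which 2 of the 4 values shown sit. The step between compound 3 and compound 4 cannot be read, so the exchange of phenyl for furan-2-yl, with its smaller ring and one added hydrogen-bond acceptor, has no measurable consequence here, and neither ring can be ranked against the other. The two readable steps, an at least 1.4-fold higher number from compound 2 to compound 4 (0.15 log units; that floor lies within the scatter) and an at least 1.2-fold higher number from compound 1 to compound 4 (0.08 log units; that floor lies within the scatter), give only floors within the scatter, so (furan-2-yl)methyl, like benzyl, is not yet separated from allyl or from the unsubstituted amide hydrogen.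

The limits leave open whether the two aromatic groups truly raise the dose needed or merely lie close to compound 1 and compound 2, and how far apart they stand. Also open, on these data alone, is what a plain methyl, a longer chain such as butyl, or a (pyridin-2-yl)methyl on this nitrogen would give in this assay.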